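The source may hold more compounds than are shown below. What is called first, only, known or untested is meant among the compounds shown, and "the series" means these compounds.

Working notes on a series of ureas sharing one core. Compound 1 `Cc1ccccc1NC(=O)Nc1cc(C(C)(C)C)nn1-c1ccccc1` in an assay on isolated protein for inhibition of serine/threonine-protein kinase 10 (Homo sapiens), read by thermal shift assay, tested at 10 uM (on this read-out lower numbers stand for weaker stabilisation of the target and higher numbers for stronger stabilisation of the target against heat), gives 8.6 degrees C; compound 2 `CC(C)(C)c1cc(NC(=O)Nc2ccc(F)cc2)n(-c2ccccc2)n1` gives 6.5 degrees C; compound 3 `Cc1ccc(F)cc1NC(=O)Nc1cc(C(C)(C)C)nn1-c1ccccc1` gives 4.1 degrees C, the lowest of the three numbers, with compound 2 nearest and compound 1 furthest, both beyond the scatter. The aryl swaps measured so far read a number 2.1 degrees C lower from compound 1 to compound 2 (beyond the scatter) and a number 2.4 degrees C lower from compound 2 to compound 3 (beyond the scatter), both modest, whereas the entry of fluorine read a number 4.5 degrees C lower from compound 1 to compound 3 (beyond the scatter), a large step. Compound 4 `COc1cccc(NC(=O)Nc2cc(C(C)(C)C)nn2-c2ccccc2)c1` differs from compound 3 by 3-methoxyphenyl in place of 5-fluoro-2-methylphenyl on an amide-type nitrogen. The fluoro that entered with a number 4.5 degrees C lower from compound 1 to compound 3 (beyond the scatter) now leaves, so a rise beyond the scatter is expected, tempered by the modest size of the aryl swaps. Compound 4 is therefore expected near 6.5 degrees C, between 4.5 degrees C and 8.5 degrees C. This corresponds to an expected step of a number 2.4 degrees C higher from compound 3 to compound 4 (beyond the scatter) in this assay.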

Compound 4, shift of the target's melting temperature: 3.7 degrees C
For compound 4 the middle estimate is 2.8 degrees C above the measured one; the measured number lies below the stated range.
By their numbers in this assay, from the lowest: compounds 4 and 3 (each within the scatter of the next); then compound 2; then compound 1.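

In this assay, 3-methoxyphenyl on the amide-type nitrogen reads a number 0.40 degrees C lower from compound 3 to compound 4 (within the scatter), so an aryl group without fluoro need not give a higher number here. The same group reads a number 2.8 degrees C lower from compound 2 to compound 4 (beyond the scatter) and a number 4.9 degrees C lower from compound 1 to compound 4 (beyond the scatter), so the fluoro-free compound 1 and compound 4 lie far apart and fluoro alone does not set the number at this position. No supporting data explain these steps.

Open, from the compounds shown here alone, is whether the number for compound 4 depends on the methoxy group itself, and whether an amine or a carboxylic acid in its place would read differently.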